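A few compounds are considered here, and "the series" means these few. Any claim that something is new, unique, unknown or untested is made for them only; others in the source may bear on it.

Compound 1 `NS(=O)(=O)NNc1nonc1/C(=N/O)Nc1ccc(F)c(Br)c1` gives 218 nM in an assay on isolated protein for inhibition of Indoleamine 2,3-dioxygenase 1 (Homo sapiens), read by fluorescence, with a stated time of 60 min; a higher number here means a weaker inhibitor, a lower number a stronger inhibitor.
Compound 2 `O=S(=O)(CCNc1nonc1/C(=N/O)Nc1ccc(F)c(Br)c1)N1CCC1` gives 191 nM in this assay.

For the measured compounds named here, of the two numbers measured so far, compound 2 has the smaller one, but the step of a 1.1-fold lower number from compound 1 to compound 2 (0.06 log units; within the scatter) is within the scatter, so compound 1 and compound 2 cannot be told apart on these data. Compound 3 `NS(=O)(=O)CCONc1nonc1/C(=N/O)Nc1ccc(F)c(Br)c1` differs from compound 2 by 2-sulfamoylethoxy in place of 2-((azetidin-1-yl)sulfonyl)ethyl on a nitrogen on an aromatic ring. Going by the values given here, only one measured step bears on this change: the group on that same ring nitrogen was also exchanged from compound 1 to compound 2, and the step of a 1.1-fold lower number from compound 1 to compound 2 (0.06 log units; within the scatter) was within the scatter. A further exchange of the group at this place is therefore expected to give no step beyond the scatter in this assay. Compound 3 is estimated at 220 nM, with a range from 90 nM to 550 nM, which means an expected step of a 1.2-fold higher number from compound 2 to compound 3 (0.06 log units; within the scatter).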

Compound 3, half-maximal inhibitory concentration: 87 nM
The estimate for compound 3 lay 2.5-fold (0.40 log units) above the measured number; measured number below the stated range.
By their numbers in this assay, from the lowest: compound 3; then compounds 2 and 1 (each within the scatter of the next).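

The group on this nitrogen can change the number in this assay: 2-sulfamoylethoxy in place of 2-((azetidin-1-yl)sulfonyl)ethyl gives a 2.2-fold lower number from compound 2 to compound 3 (0.34 log units; beyond the scatter), and 2-sulfamoylethoxy in place of sulfamoylamino gives a 2.5-fold lower number from compound 1 to compound 3 (0.40 log units; beyond the scatter). For the compounds shown here, the earlier exchange at this place stayed within the scatter, so compound 3 is the first sign that this position does not respond alike to every group. No measurement shown here explains this difference.

Compound 3 differs from compound 2 in both the ethoxy link and the sulfonyl end, so the compounds shown cannot separate the two; 2-((azetidin-1-yl)sulfonyl)ethoxy would test this directly. Going by these compounds, it also remains open how a longer chain, or a carboxylic acid in place of the sulfamoyl end, would behave at this nitrogen.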